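The source may hold more compounds than are shown below. What is called first, only, known or untested is meant among the compounds shown, and "the series" means these compounds.

In a functional assay on HeLa cells (Homo sapiens) for antiproliferative activity, read by CCK-8 assay, with a stated time of 72 h (a higher number here means a weaker inhibitor, a lower number a stronger inhibitor), compound 1 `COc1ccc(SCc2ccc(C(=O)Nc3ccccc3N)cc2)cc1` gives 2390 nM, compound 2 `Nc1ccccc1NC(=O)c1ccc(CSc2cccc(F)c2)cc1` gives 3240 nM and compound 3 `Nc1ccccc1NC(=O)c1ccc(CSCCc2ccccc2)cc1` gives 6430 nM. Compound 3 therefore sits within the scatter of one neighbour, with a 2.0-fold higher number from compound 2 to compound 3 (0.30 log units; within the scatter), and clear of the other, with a 2.7-fold higher number from compound 1 to compound 3 (0.43 log units; beyond the scatter). Compound 4 `Nc1ccccc1NC(=O)c1ccc(CSc2ccc(F)cc2)cc1` has 4-fluorophenyl in place of phenethyl on a sulfur. Read backwards, those two steps are the closest guides: each puts phenethyl where a substituted phenyl stood. Exchanging one such phenyl for another stayed within the scatter, with a 1.4-fold higher number from compound 1 to compound 2 (0.13 log units; within the scatter). A lower number is therefore expected, with an estimated 2.0-fold lower number from compound 3 to compound 4 (0.30 log units; within the scatter), near the edge of the scatter. Compound 4 is estimated at 3200 nM, with an expected range of 1600 nM to 6400 nM.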

Compound 4, half-maximal inhibitory concentration: 5010 nM
Compound 4: middle estimate off by 1.6-fold (0.19 log units), on the low side, within the range that was stated.
By their numbers in this assay, from the lowest: compounds 1, 2, 4 and 3 (each within the scatter of the next, the first and the last beyond it).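

In this assay, 4-fluorophenyl in place of phenethyl on the sulfur gives a 1.3-fold lower number from compound 3 to compound 4 (0.11 log units; within the scatter), so this pair does not separate the two groups. Moving from 3-fluorophenyl to 4-fluorophenyl gives a 1.5-fold higher number from compound 2 to compound 4 (0.19 log units; within the scatter), so these two fluorophenyl groups cannot be told apart either. Only fluoro in place of methoxy on the aromatic carbon clears the scatter, modestly, with a 2.1-fold higher number from compound 1 to compound 4 (0.32 log units; beyond the scatter).

Nothing measured here explains these differences. From the compounds shown here alone, whether an amine or a carboxylic acid in place of the fluoro, or a longer chain on the sulfur, would shift the number further remains open.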